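From 4-nitrophenyl to 2-fluorophenyl on the shared core

This account rests on a few compounds, and the source may have more. Where it says the series, first, only, none or still open, it means among the compounds named here.

In a functional assay on HeLa cells (Homo sapiens) for cytotoxicity, read by WST assay, with a stated time of 48 h (on this read-out lower numbers stand for stronger inhibition and higher numbers for weaker inhibition), compound 1 (`Cc1ccc(/C=C/C[C@H]2C[C@@H]([C@@H](O)c3ccccc3)CO[C@@H]2c2ccccc2)cc1C`) gives 10000 nM, and compound 2 (`O=[N+]([O-])c1ccc(/C=C/C[C@H]2C[C@@H]([C@@H](O)c3ccccc3)CO[C@@H]2c2ccccc2)cc1`) gives 12400 nM, so compound 2 stands within the scatter of compound 1. Compound 3 (`O[C@@H](c1ccccc1)[C@H]1CO[C@H](c2ccccc2)[C@@H](C/C=C/c2ccccc2F)C1`) carries 2-fluorophenyl in place of 4-nitrophenyl on a double-bonded chain carbon bound to a double-bonded chain carbon. Among the measured compounds shown here, the only measured step at this place, a 1.2-fold higher number from compound 1 to compound 2 (0.09 log units; within the scatter), stayed small, so no step beyond the scatter is expected. The estimated step is a 1.2-fold lower number from compound 2 to compound 3 (0.09 log units; within the scatter). For compound 3 the expected value is 10000 nM, with an estimated range of 4000 nM to 25000 nM.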

Compound 3, half-maximal inhibitory concentration: 9730 nM
Estimate against measurement, compound 3: 1.0-fold (0.01 log units) above, within the range that was stated.
By their numbers in this assay, from the lowest: compounds 3, 1 and 2 (each within the scatter of the next).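

With 2-fluorophenyl at this place, this assay shows a 1.3-fold lower number from compound 2 to compound 3 (0.11 log units; within the scatter) and also a 1.0-fold lower number from compound 1 to compound 3 (0.01 log units; within the scatter) as its second step. The place on a double-bonded chain carbon bound to a double-bonded chain carbon thus now holds 4-nitrophenyl, 3,4-dimethylphenyl and 2-fluorophenyl, with all three compounds within the scatter of each other. No evidence at hand accounts for this result. As far as these compounds go, whether an aminophenyl or a carboxyphenyl group here would give a step beyond the scatter stays open, as does the outcome of a longer chain carrying the ring.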